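One Methyl Step from Compound 3 to Compound 4

A few compounds are considered here, and "the series" means these few. Any claim that something is new, unique, unknown or untested is made for them only; others in the source may bear on it.

Measured so far in a physicochemical assay for lipophilicity; a lower number here means a more polar compound, a higher number a more lipophilic compound:
Compound 1, `CNC(=O)c1cc(C(=O)N[C@H]2CC[C@H](O)CC2)n([C@@H](C)c2cccc(Cl)c2)n1`: 3.7
Compound 2, `CNC(=O)c1cc(C(=O)N[C@H]2[C@@H]3C[C@@H](O)C[C@@H]32)n([C@@H](C)c2ccccc2)n1`: 3.2
Compound 3, `CNC(=O)c1cc(C(=O)NC2CC2)n(Cc2ccccc2)n1`: 3.1

Compound 3 carries the lowest of the three numbers. Compound 2 sits close to it, within the usual scatter, so no order can be read between those two. Compound 1 stands clearly higher, beyond the scatter. Compound 4, `CNC(=O)c1cc(C(=O)NC2CC2)n([C@@H](C)c2ccccc2)n1`, has not yet been measured. It differs from compound 3 in one place: methyl in place of hydrogen on a saturated chain carbon bound to an aromatic carbon and an aromatic nitrogen. Among the measured compounds shown here, no pair of measured compounds differs in this way, so the size of the step must be estimated. A modest rise in this assay is expected, larger than the scatter yet small; the expected step is a number 0.40 log units higher from compound 3 to compound 4 (beyond the scatter). Compound 4 is therefore estimated at 3.5, with a range from 3.2 to 3.8.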

Compound 4, distribution coefficient: 3.6
Compound 4: middle estimate off by 0.10 log units, on the low side; the measured number falls inside the stated range.
By their numbers in this assay, from the lowest: compounds 3 and 2 (each within the scatter of the next); then compounds 4 and 1 (each within the scatter of the next).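

In this assay, methyl in place of hydrogen on this saturated chain carbon now has a measured step of its own, a number 0.50 log units higher from compound 3 to compound 4 (beyond the scatter) and it lies beyond the scatter. On the amide-type nitrogen, a group of 3 heavy atoms in place of a group of 7 heavy atoms gives a number 0.40 log units higher from compound 2 to compound 4 (beyond the scatter) and so also lies beyond the scatter. Nothing shown gives a cause for either step.

Going by these compounds, an ethyl group or a longer chain on this carbon remains open. So does the effect of the same methyl change when the group of 7 heavy atoms sits on the amide-type nitrogen.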